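The source may hold more compounds than are shown below. What is called first, only, known or untested is meant among the compounds shown, and "the series" means these compounds.

Measured so far:
compound 1 `Cc1cc(C)c(CN2CCc3ccc(-c4c(C)noc4C)c(Cl)c3C2=O)c(=O)[nH]1`: 3.2 nM
compound 2 `Cc1cc(C)c(CN2CCc3c(Cl)cc(-c4cn[nH]c4C)c(Cl)c3C2=O)c(=O)[nH]1`: 24 nM

Among the two compounds measured in an assay on Sf9 cells for inhibition of histone-lysine N-methyltransferase EZH2 (Homo sapiens), read by scintillation counting, with a stated time of 60 min, in the presence of a further agent that is not named here (on this read-out higher numbers stand for weaker inhibition and lower numbers for stronger inhibition), compound 2 has the highest number; compound 1 sits well below it, beyond the usual scatter. Compound 3 `Cc1cc(C)c(CN2CCc3c(Cl)cc(-c4c(C)n[nH]c4C)c(Cl)c3C2=O)c(=O)[nH]1` differs from compound 2 in one place: methyl in place of hydrogen on an aromatic carbon. Among the measured compounds shown here, no step between two measured compounds matches this change, so the expectation rests on the change itself. A small step toward stronger inhibition is expected, at about the edge of the scatter. Compound 3 is therefore expected to give 12 nM, between 4 nM and 40 nM, which means an expected step of a 2.0-fold lower number from compound 2 to compound 3 (0.30 log units; within the scatter).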

Compound 3, half-maximal inhibitory concentration: 16 nM
Compound 3: middle estimate off by 1.3-fold (0.12 log units), on the low side; the range from low to high includes it.
By their numbers in this assay, from the lowest: compound 1; then compounds 3 and 2 (each within the scatter of the next).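

Replacing 5-methyl-1H-pyrazol-4-yl with 3,5-dimethyl-1H-pyrazol-4-yl gives a step in this assay of a 1.5-fold lower number from compound 2 to compound 3 (0.18 log units; within the scatter). Among the compounds shown here, this aromatic carbon therefore accepts methyl in place of hydrogen with no clear gain or loss of inhibition, something the earlier compounds could not show. Nothing available explains this result. On these data alone, whether an ethyl group, a longer chain or an amine on this carbon would be accepted in the same way remains open. So does whether this methyl would have a similarly small effect on a different core.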